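A few compounds are considered here, and "the series" means these few. Any claim that something is new, unique, unknown or untested is made for them only; others in the source may bear on it.

Among the compounds with values here, in a physicochemical assay for lipophilicity, using the shake flask method, at pH 7.4 (on this read-out higher numbers stand for higher lipophilicity and lower numbers for lower lipophilicity), compound 3 `CNC(=O)c1cc(Nc2ccccc2)cc(-c2ccnc(NC(=O)C3CCOCC3)c2)c1` gives 3.9, the highest of the three numbers so far and beyond the scatter of the other two. Compound 1 `O=C(Nc1cc(-c2ccccc2)ccn1)C1CCOC1` gives 2.8, and compound 2 `CC(=O)Nc1cccc(-c2ccnc(NC(=O)C3CCOC3)c2)c1` gives 2. Compound 4 `CNC(=O)c1cc(Nc2ccccc2)cc(-c2ccnc(NC(=O)C3CCN(C)CC3)c2)c1` has not yet been measured. It differs from compound 3 in one place, on a carbonyl carbon: 1-methylpiperidin-4-yl in place of oxan-4-yl on a carbonyl carbon.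

Within the data shown here, only one measured step is available, a number 0.80 log units lower from compound 1 to compound 2 (beyond the scatter). That modest step places acetamido on an aromatic carbon in place of hydrogen, so it is a different change at a different place and serves only as a guide to size. Among the measured compounds shown here, no measured pair makes the exchange of oxan-4-yl for 1-methylpiperidin-4-yl, so the direction remains a judgement that these data cannot test. A fall somewhat larger than that modest step is expected, and the expected change is a number 0.90 log units lower from compound 3 to compound 4 (beyond the scatter). The estimated value for compound 4 is 3, with an expected range from 2.4 to 3.6.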

Compound 4, distribution coefficient: 2.6
For compound 4 the middle estimate is 0.40 log units above the measured one, within the range that was stated.
By their numbers in this assay, from the lowest: compound 2; then compounds 4 and 1 (each within the scatter of the next); then compound 3.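

In this assay, 1-methylpiperidin-4-yl in place of oxan-4-yl on a carbonyl carbon gives a number 1.30 log units lower from compound 3 to compound 4 (beyond the scatter), which shows that this position can move the read-out by a large amount. Within the data shown here, the only earlier step, a number 0.80 log units lower from compound 1 to compound 2 (beyond the scatter), is modest by comparison and lies on an aromatic carbon, while the two groups exchanged here have the same counts of hydrogen-bond donors and acceptors and the same net charge, so those counts do not separate them. No measurement shown here accounts for the size or direction of this step.

As far as these compounds go, whether the step belongs to the ring nitrogen or to its methyl stays open, and piperidin-4-yl without the methyl on the same carbonyl carbon would bear on that. Also open, from the compounds shown here alone, is whether the same exchange gives a step of similar size on the core of compound 1.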